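This account rests on a few compounds, and the source may have more. Where it says the series, first, only, none or still open, it means among the compounds named here.

Compound 1 `CC(=O)/C(=C/c1c(-c2ccccc2)[nH]c2ccccc12)C(=O)c1ccccc1`: in an ADME assay on CRL-7065 cells (Homo sapiens) for cytotoxicity, read by MTT assay, with a stated time of 96 h (on this read-out higher numbers stand for an effect only at larger amounts of compound and lower numbers for an effect already at smaller amounts), compound 1 gives > 100000 nM, which is a limit of the assay and not a number.
Compound 2 `CCOC(=O)/C(=C/c1c(-c2ccccc2)[nH]c2ccccc12)C(=O)c1ccc([N+](=O)[O-])cc1`: in this assay compound 2 gives > 100000 nM, again a limit of the assay rather than a number.

Neither compound showed the effect within the range that was tested, so for both only the end of the range is known. Among the measured compounds shown here, compound 2 therefore stands at the limit of > 100000 nM in this assay, at which 2 of the 2 values shown sit, and the one further value shown sits at that same limit. For the measured compounds named here, because both values are limits, no step between measured compounds can be given.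

Compound 3 `CCOC(=O)/C(=C/c1c(-c2ccccc2)[nH]c2ccccc12)C(=O)c1ccccc1` has not yet been measured in this assay. It differs from compound 2 in one place: hydrogen in place of nitro on an aromatic carbon. Nothing measured here shows what this change does. Going by the values given here, the only guide is the position of compound 2 at the limit. The step expected in this assay from compound 2 to compound 3, a step that the limit leaves unreadable from compound 2 to compound 3, is therefore none beyond the usual scatter, in no particular direction. Compound 3 is estimated at 150000 nM, within 50000 nM to 500000 nM, and the measurement is expected most likely to return only a limit again.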

Compound 3, half-maximal effective concentration: > 100000 nM
Compound 3: no number, only a limit; the forecaster's own chance of this, stated with the estimate: 80%; the middle value does not contradict the limit.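

In this assay, compound 3 gives only a limit and not a number, as do compound 1 and compound 2, so the steps from compound 1 and from compound 2 to compound 3 cannot be read: the limit of > 100000 nM in this assay, at which 3 of the 3 values shown sit. The compounds shown leave open at what amount any effect would begin, and whether either change alters it.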